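This account rests on a few compounds, and the source may have more. Where it says the series, first, only, none or still open, it means among the compounds named here.

Measured compounds:
Compound 1, `CCCS(=O)(=O)N1CCN(c2ccc(OCC3CCN(C(=O)NC(C)C)CC3)cn2)CC1`, in a functional assay on CHO-K1 cells for agonist activity at Glucose-dependent insulinotropic receptor (Homo sapiens), read by a luciferase reporter, with a stated time of 5 h (on this read-out higher numbers stand for an effect only at larger amounts of compound and lower numbers for an effect already at smaller amounts), gives 1000 nM.
Compound 2, `CCCS(=O)(=O)N1CCN(c2ccc(OCC3CCN(C(=O)CC(C)C)CC3)cn2)CC1`, in this assay gives 1600 nM.
Compound 3, `CCCS(=O)(=O)N1CCN(c2ccc(OCC3CCN(C(=O)NC4CCCCC4)CC3)cn2)CC1`, in this assay gives only a limit, > 10000 nM.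

Compound 3 thus stands at the edge of what this assay reports: its value is the limit of > 10000 nM in this assay, at which 1 of the 3 values shown sits, not a number. Compound 4, `CCCS(=O)(=O)N1CCN(c2ccc(OCC3CCN(C(=O)N4CCOCC4)CC3)cn2)CC1`, differs from compound 3 in one place: morpholin-4-yl in place of cyclohexylamino on a carbonyl carbon. For the measured compounds named here, two measured steps bear on this change. The step of an at least 10-fold higher number from compound 1 to compound 3 (1.00 log units; beyond the scatter) and the step of an at least 6.2-fold higher number from compound 2 to compound 3 (0.79 log units; beyond the scatter) both run toward compound 3 and both lie beyond the scatter, and both end at the same limit, so they give only a lower bound for how far compound 3 lies from compounds 1 and 2. The change to compound 4 removes the cyclohexyl ring that those two steps brought in and puts a six-membered ring with two hetero atoms and no hydrogen-bond donor in its place. The expected step in this assay is an at least 4.0-fold lower number from compound 3 to compound 4 (0.60 log units; beyond the scatter), bringing compound 4 back toward compounds 1 and 2 without clearly reaching them. For compound 4 the estimate is 2500 nM, with a range from 800 nM to 8000 nM.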

Compound 4, half-maximal effective concentration: > 10000 nM
Compound 4 gave a limit, no number; the forecaster's own chance of this, stated with the estimate: 25%; middle value at least 4.0-fold (0.60 log units) from the limit.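

In this assay compound 4 gives > 10000 nM, which is a limit and not a number. Morpholin-4-yl in place of isobutyl gives an at least 6.2-fold higher number from compound 2 to compound 4 (0.79 log units; beyond the scatter), and in place of isopropylamino it gives an at least 10-fold higher number from compound 1 to compound 4 (1.00 log units; beyond the scatter), so on this carbonyl carbon a six-membered ring goes with a limit whether it is of carbon only and carries 1 hydrogen-bond donor, as in compound 3, or has 2 hetero atoms and carries none, as in compound 4. The step from compound 3 to compound 4 cannot be read, and the two rings cannot be ranked against each other: the limit of > 10000 nM in this assay, at which 2 of the 4 values shown sit.

From the compounds shown here alone, it remains open whether a four-membered ring such as azetidin-1-yl or a cyclopropylamino group would return a measurable value here. Equally open, going by these compounds, is how a longer chain such as n-butyl would read out on this carbonyl carbon.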